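From Hydroxy to Methyl: A Question of Cell Toxicity

The compounds below may be only part of what the source reports. "The series", "measured", "known", "first", "only" and "open" are said of these compounds alone.

In an ADME assay on HEK293 cells (Homo sapiens) for cytotoxicity, read by resazurin assay, with a stated time of 48 h (on this read-out lower numbers stand for higher toxicity in this test and higher numbers for lower toxicity in this test), compound 1 `O=S(=O)(Nc1ccc(-c2nc3ccccc3o2)cc1)c1ccccc1O` gives > 100000 nM as its reading, which is a limit of the assay and not a number. Compound 2 `O=S(=O)(Nc1ccc2oc(-c3ccccc3)nc2c1)c1ccc(Cl)c(Cl)c1` gives 71000 nM as a true measured number. Compound 3 `Cc1ccccc1S(=O)(=O)Nc1ccc(-c2nc3ccccc3o2)cc1` keeps the core of compound 1 and alters a single group, and it has not yet been measured. The difference is methyl in place of hydroxy on an aromatic carbon and amounts to methyl in place of hydroxy on an aromatic carbon, ortho to a large group. Among the compounds with values here, no pair of measured compounds shows this change on its own, so the size of the step has to be judged with little support. A small step towards lower numbers is expected, possibly none beyond the scatter, and compound 3 may well stay at the limit. Within the data shown here, the only real number to lean on is that of compound 2 at 71000 nM on the same read-out. The estimated value for compound 3 is 80000 nM (expected range 30000 nM to 200000 nM). That estimate means an at least 1.2-fold lower number from compound 1 to compound 3 (0.09 log units; that floor lies within the scatter) as the expected step.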

Compound 3, half-maximal cytotoxic concentration: > 100000 nM
Compound 3 gave a limit, no number; the forecaster's own chance of this, stated with the estimate: 50%; at least 1.2-fold (0.09 log units) between middle value and limit.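

Within the data shown here, compound 1 and compound 3 each gave a limit and not a number, so no step from one to the other can be read in this assay: the limit of > 100000 nM in this assay, at which 2 of the 3 values shown sit.

The compounds shown leave open whether methyl in place of hydroxy changes the reading in this assay at all, and if it does, in which direction and by how much.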